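The source may hold more compounds than are shown below. What is called first, only, known or untested is meant among the compounds shown, and "the series" means these compounds.

In an ADME assay on L6 cells (Rattus norvegicus) for cytotoxicity (on this read-out lower numbers stand for stronger inhibition and higher numbers for weaker inhibition), compound 1 `O=C(NN1CCc2ccccc2C1)c1cc([N+](=O)[O-])ccc1Cl` gives 22000 nM, compound 2 `O=C(NN(Cc1ccccc1)Cc1ccccc1)c1ccccc1Cl` gives 50700 nM and compound 3 `O=C(NN(Cc1ccccc1)Cc1ccccc1)c1cc([N+](=O)[O-])ccc1Cl` gives 41700 nM. Compound 3 stands within the scatter of both compound 1 and compound 2, so it has no distinct place among the three numbers.

Compound 4 `O=C(NN(Cc1ccccc1)Cc1ccccc1)c1cc([N+](=O)[O-])ccc1F` differs from compound 3 in one place, with fluoro in place of chloro on an aromatic carbon, para to a nitro group: fluoro in place of chloro on an aromatic carbon.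

Among the compounds with values here, no measured compound carries this fluoro, so no measured step tests the exchange directly. Within the data shown here, the nearest evidence is the only single-place step, a 1.2-fold lower number from compound 2 to compound 3 (0.08 log units; within the scatter), where nitro replaces hydrogen on an aromatic carbon. That step stays within the scatter, and it is a different kind of change, so it offers only weak guidance. No step beyond the scatter is therefore expected in this assay, and no direction is firmly expected. The estimated step is a 1.2-fold lower number from compound 3 to compound 4 (0.06 log units; within the scatter). Compound 4 is estimated at 36000 nM, with an expected range of 16000 nM to 75000 nM.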

Compound 4, half-maximal inhibitory concentration: 19300 nM
Compound 4: the middle estimate sits 1.9-fold (0.27 log units) above what was measured; measured number inside the range.
By their numbers in this assay, from the lowest: compounds 4, 1, 3 and 2 (each within the scatter of the next, the first and the last beyond it).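

In this assay, within the data shown here, the aromatic carbon para to a nitro group and ortho to a large group is the first place where a single exchange moves the number beyond the scatter: a 2.2-fold lower number from compound 3 to compound 4 (0.33 log units; beyond the scatter), with fluoro in place of chloro. Among these compounds, the only earlier single-place step, a 1.2-fold lower number from compound 2 to compound 3 (0.08 log units; within the scatter), stayed within the scatter, so the series now holds one modest change, and it rests on this one pair. Nothing available accounts for this step.

From the compounds shown here alone, whether fluoro in place of chloro gives a similar step on the core of compound 1, or without the nitro group, remains open. Also open, going by these compounds, is how a methoxy group or an amine on this same carbon would read.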